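Adding a Chloro Group to the Benzyl Arm

The source may hold more compounds than are shown below. What is called first, only, known or untested is meant among the compounds shown, and "the series" means these compounds.

Measured so far:
Compound 1 `CC1=C(C(=O)Nc2ccc(Br)cc2)C(c2ccc(Cl)cc2Cl)N=C(SCc2ccccc2)N1` gives 8.2% in a functional assay on the whole organism (artery, strain albino) with Rattus norvegicus as the target, with a stated time of 900 min, at a dose of 10 mg/kg by the oral route; a higher number here means more inhibition at the dose given (going by the name of the read-out), a lower number less inhibition.
Compound 2 `COc1ccc(C2N=C(SCc3ccccc3)NC(C)=C2C(=O)Nc2ccc(Br)cc2)cc1` gives 5.6% in this assay.

Compound 2 stands lowest of the two numbers in this assay, though its step to compound 1 is small: a number 2.6 percentage points lower from compound 1 to compound 2 (within the scatter), which lies within the scatter, so the two values cannot be told apart. Both compounds show only slight inhibition at the dose given.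

Compound 3 `COc1ccc(C2N=C(SCc3ccc(Cl)cc3)NC(C)=C2C(=O)Nc2ccc(Br)cc2)cc1` has not been measured. It differs from compound 2 by chloro in place of hydrogen on an aromatic carbon, so the change sits on an aromatic carbon of a six-membered aromatic ring of carbon only, in the benzylsulfanyl part rather than on the saturated ring carbon that was changed between compound 1 and compound 2.

Among the measured compounds shown here, no measured step touches the benzyl arm, so nothing here shows what a chloro group in that place does. For the measured compounds named here, the only step known, from compound 1 to compound 2, was within the scatter. Compound 3 is therefore expected to stay close to compound 2, with a step of a number 0.4 percentage points higher from compound 2 to compound 3 (within the scatter) in this assay, none beyond the scatter. The estimate for compound 3 is 6%, with a range from -4% to 16%.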

Compound 3, a percentage reported as inhibition, in the whole organism at one dose (the size of the read-out at that dose, not a potency): 20%
Estimate against measurement, compound 3: 14 percentage points below, and the stated range ends below it.
By their numbers in this assay, from the lowest: compounds 2 and 1 (each within the scatter of the next); then compound 3.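

The benzyl arm proves to be a place where a single small change registers: swapping benzyl for 4-chlorobenzyl, with chloro in place of hydrogen on an aromatic carbon, gives in this assay a number 14.4 percentage points higher from compound 2 to compound 3 (beyond the scatter). Among the compounds shown here, the earlier compounds could not show this, since their only step, a number 2.6 percentage points lower from compound 1 to compound 2 (within the scatter), came from a change on the saturated ring carbon and left the two values indistinguishable, whereas this change on the benzylsulfanyl part is the only step in the set to clear the scatter. Nothing available explains why a chloro group at this place goes with more inhibition, so the result stands as an observation only.

From the compounds shown here alone, it remains open whether chlorine itself matters or whether another group on the same aromatic carbon, such as fluoro, methyl, methoxy or an amine, would do as well or better. Going by these compounds, it is also open whether the same swap to 4-chlorobenzyl would raise the number when the 2,4-dichlorophenyl group of compound 1 sits on the saturated ring carbon instead of the 4-methoxyphenyl group.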